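The compounds below may be only part of what the source reports. "The series", "measured", "known", "first", "only" and "open" are said of these compounds alone.

Measured compounds:
compound 1 `COc1cc(CC[C@H](C[C@H](O)CCc2ccc(O)cc2)O[C@@H]2O[C@H](CO)[C@@H](O)[C@H](O)[C@H]2O)ccc1O`, 160 ug/mL
compound 2 `COc1cc(CC[C@@H](O)C[C@H](O)CCc2ccc(O)cc2)ccc1O`, "not determined" (no result reported)

In a functional assay on HSC-2 cells (Homo sapiens) for cytotoxicity, read by MTT assay (on this read-out higher numbers stand for weaker inhibition and lower numbers for stronger inhibition), compound 1 gives 160 ug/mL. Among the compounds with values here, compound 2 has "not determined" (no result reported), so compound 1 carries the only number here, and no step between measured compounds can be drawn. Compound 3 `COc1cc(CC[C@@H](O)C[C@@H](CCc2ccc(O)c(OC)c2)O[C@@H]2O[C@H](CO)[C@@H](O)[C@H](O)[C@H]2O)ccc1O` has not yet been measured. It differs from compound 1 in one place: methoxy in place of hydrogen on an aromatic carbon. Within the data shown here, nothing among the measured compounds shows how such a change acts in this setting, so the expected step of no change at the digits printed from compound 1 to compound 3 (within the scatter) is none beyond the usual scatter. Compound 3 is therefore estimated at 160 ug/mL, in a range from 80 ug/mL to 320 ug/mL.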

Compound 3, half-maximal inhibitory concentration: 198 ug/mL
Compound 3: the middle estimate sits 1.2-fold (0.09 log units) below what was measured, within the range that was stated.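

In this assay, methoxy in place of hydrogen on this aromatic carbon, ortho to a hydroxy group, gives a 1.2-fold higher number from compound 1 to compound 3 (0.09 log units; within the scatter) and so stays within the usual scatter. Within the data shown here, this position therefore accepts a methoxy group with no difference that this read-out can separate from ordinary repeat variation, something the earlier compounds could not show. No measured information here explains this result. On these data alone, whether an ethoxy group, an amine or a carboxylic acid on the same carbon would behave alike remains open.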